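Phenyl for Benzyl on a Well-Tolerated Scaffold

The compounds below may be only part of what the source reports. "The series", "measured", "known", "first", "only" and "open" are said of these compounds alone.

The study assessed how much compound the cells tolerate in an ADME assay on Huh-7 cells (Homo sapiens) for cytotoxicity; a higher number here means that more compound is tolerated, a lower number that less compound is tolerated. Compound 1, `CN1CCN(CCCNCc2cn(-c3ccc([N+](=O)[O-])cc3)nc2-c2ccc(Cl)cc2)CC1`, gives 3700 nM in this assay. Among the measured compounds shown here, compound 2, `CN1CCN(CCNCc2cn(-c3ccc(F)cc3F)nc2Cc2ccccc2)CC1`, differs from compound 1 in several places, so no single step links the two, and the two values can only be set side by side. Compound 2 reaches > 20000 nM in this assay, which is a limit of the assay rather than a number. Compound 2 therefore stands at the limit of > 20000 nM in this assay, at which 1 of the 2 values shown sits. Compound 3, `CN1CCN(CCNCc2cn(-c3ccc(F)cc3F)nc2-c2ccccc2)CC1`, remains to be measured. Its change from compound 2 is phenyl in place of benzyl on an aromatic carbon. For the measured compounds named here, no step between measured compounds is recorded for a change of this kind, so the size of the step cannot be read from the data; the change is small, and the expectation is a step no larger than the scatter, with no clear direction. The expected step is a step that the limit leaves unreadable from compound 2 to compound 3. Compound 3 is estimated at 25000 nM in this assay, with a range from 10000 nM to 60000 nM, and a further limit is judged likely.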

Compound 3, half-maximal cytotoxic concentration: > 20000 nM
Compound 3: a limit, no number (the forecaster's own chance of this, stated with the estimate: 60%); the middle value lies beyond the limit too.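

No step can be read from compound 2 to compound 3 in this assay, because each of the two values is a limit of the assay and not a number: the limit of > 20000 nM in this assay, at which 2 of the 3 values shown sit. The compounds shown leave open whether phenyl in place of benzyl on an aromatic carbon changes the result in this assay at all.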